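Bromo to aryl replacement on the shared core: expected inhibition

A few compounds are considered here, and "the series" means these few. Any claim that something is new, unique, unknown or untested is made for them only; others in the source may bear on it.

Compound 1 `Brc1cn2ccnc2c(-c2ccc3ncn(C4CCCCC4)c3c2)n1` is the reference point for this step. For the measured compounds named here, in a functional assay on UO-31 cells (Homo sapiens) for inhibition, read by sulforhodamine B assay, with a stated time of 48 h, tested at 10 uM (on this read-out higher numbers stand for more inhibition at the one concentration tested (going by the name of the read-out) and lower numbers for less inhibition), compound 1 gives 37.6%, the lowest of the two numbers so far; its nearest neighbour is compound 2 `c1ccc(-c2cn3ccnc3c(-c3ccc4ncn(C5CCCCC5)c4c3)n2)cc1`, which in this assay gives 55.2%.

Going by the values given here, the one measured step that bears on the question is a number 17.6 percentage points higher from compound 1 to compound 2 (beyond the scatter), so putting an aromatic ring where the bromo sits has so far moved the read-out upward by a modest amount.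

Compound 3 `Brc1ccc(-c2cn3ccnc3c(-c3ccc4ncn(C5CCCCC5)c4c3)n2)cc1` is the next compound. It differs from compound 1 in the following way: 4-bromophenyl in place of bromo on an aromatic carbon. Among the compounds with values here, the entering group is a ring of the same size as the phenyl of compound 2, carrying bromine on that ring; no measured pair shows what adding bromine to such a ring does here.

Given that compound 1 gives 37.6% and compound 2 gives 55.2%, the step to compound 3 is expected to resemble the phenyl step, estimated as a number 16.4 percentage points higher from compound 1 to compound 3 (beyond the scatter). Compound 3 is accordingly expected to give 54%, with a range of 40% to 68%.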

Compound 3, a percentage reported as inhibition, at one concentration (the size of the read-out at that concentration, not a potency): 42.9%
Beside the measured number, compound 3's estimate is 11.1 percentage points above it; measured number inside the range.
By their numbers in this assay, from the lowest: compounds 1 and 3 (each within the scatter of the next); then compound 2.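

In this assay, an aromatic ring at this position does not carry the gain by itself: a number 5.3 percentage points higher from compound 1 to compound 3 (within the scatter), which leaves the 4-bromophenyl compound within the scatter of the bromo compound, even though the phenyl ring of compound 2 stood clearly apart from it. For the compounds shown here, the first change on the entering ring itself also matters, since bromo in place of hydrogen gives a number 12.3 percentage points lower from compound 2 to compound 3 (beyond the scatter), so the read-out at this position depends on what the aromatic ring carries and not only on its presence. Nothing available offers an explanation for this loss on adding bromine to the ring.

Going by these compounds, it remains open whether the loss is specific to bromine or would also follow from another substituent on the phenyl ring, such as fluoro, methoxy or an amine. Also open, on these data alone, is how a non-aromatic group at this place, such as morpholine or a short alkyl chain, would compare with bromo and phenyl, and all of these readings rest on a single concentration rather than on a potency.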